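A few compounds are considered here, and "the series" means these few. Any claim that something is new, unique, unknown or untested is made for them only; others in the source may bear on it.

Measured so far:
compound 1 `CCOC(=O)c1cccc(NC(=O)N[C@@H](C)c2ccccc2)c1`: 99%
compound 2 `COc1cccc(NC(=O)N[C@@H](C)c2ccccc2)c1`: 99%
compound 3 `C[C@H](NC(=O)Nc1cccc(F)c1)c1ccccc1`: 94%

In an ADME assay on the whole organism with Oryza sativa as the target, tested at 1 uM (on this read-out higher numbers stand for a weaker effect at the one concentration tested and lower numbers for a stronger effect), compound 1 gives 99% and compound 2 gives 99%; in this assay compound 3 gives 94%. Compound 3 carries the lowest of the three numbers, yet its gap to compound 1 and to compound 2 is within the scatter, so no order among the three can be read from these values. The single-point exchanges seen so far are flat: no change at the digits printed from compound 1 to compound 2 (within the scatter), a number 5 percentage points lower from compound 1 to compound 3 (within the scatter) and a number 5 percentage points lower from compound 2 to compound 3 (within the scatter).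

Compound 4 `C[C@H](NC(=O)Nc1cccc(Br)c1)c1ccccc1` is the next member; its difference from compound 3 is bromo in place of fluoro on an aromatic carbon. Among the compounds with values here, the steps that bear on this exchange are those ending at the fluoro compound, from compound 1 and from compound 2, and both stayed within the scatter although they changed the group on this same aromatic carbon. Within the data shown here, no measured step swaps one halogen for another, so nothing here argues for a move beyond the scatter in either direction. Compound 4 is therefore expected to give about 94%, with a range of 82% to 100%. The expected step is no change at the digits printed from compound 3 to compound 4 (within the scatter), that is, no change beyond the scatter.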

Compound 4, a percentage reported as activity, at one concentration (the size of the read-out at that concentration, not a potency): 100%
For compound 4 the middle estimate is 6 percentage points below the measured one; measured number inside the range.
By their numbers in this assay, from the lowest: compounds 3, 1, 2 and 4 (each within the scatter of the next).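

In this assay a halogen exchange on this aromatic carbon is now measured directly, and it gives a number 6 percentage points higher from compound 3 to compound 4 (within the scatter) and so no separation between bromo and fluoro. Bromo also stays level with methoxy and ethoxycarbonyl, with a number 1 percentage points higher from compound 2 to compound 4 (within the scatter) and a number 1 percentage points higher from compound 1 to compound 4 (within the scatter) as the steps, so all four groups at this place lie within the scatter of one another. No available evidence bears on this flat result.

Open: whether any group at this place moves the number beyond the scatter, with an amine, a carboxylic acid or a longer chain as candidates. As far as these compounds go, also open: whether a change elsewhere on the shared core does so, since these compounds differ only at this one aromatic carbon.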